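A Longer Chain Carrying One Double Bond

The compounds below may be only part of what the source reports. "The series", "measured", "known", "first", "only" and "open" are said of these compounds alone.

In a functional assay on A549 cells (Homo sapiens) for inhibition, read by MTT assay (a higher number here means a weaker inhibitor, a lower number a stronger inhibitor), compound 1 (`CCCCCCCCCCCC(=O)OC1=C(CC=C(C)C)C(=O)c2ccccc2C1=O`) gives 35000 nM, and compound 2 (`CCCCCCCCCCCCCC(=O)OC1=C(CC=C(C)C)C(=O)c2ccccc2C1=O`) gives 49000 nM, so the two sit within the scatter of each other. Compound 3 (`CCCCCCCCCCCCCCCCCC(=O)OC1=C(CC=C(C)C)C(=O)c2ccccc2C1=O`) returns only a limit of the assay, > 100000 nM. Compound 4 (`CCCCCCCC/C=C\CCCCCCCC(=O)OC1=C(CC=C(C)C)C(=O)c2ccccc2C1=O`) differs from compound 1 by dec-1-en-1-yl in place of butyl on a saturated chain carbon, seven bonds along the chain from a carbonyl carbon. The closest guides are the chain extensions: a 1.4-fold higher number from compound 1 to compound 2 (0.15 log units; within the scatter), and an at least 2.8-fold higher number from compound 1 to compound 3 (0.45 log units; beyond the scatter). Going by the values given here, none of the measured compounds carries a double bond, so the guidance is loose. A modest rise is expected, with the estimated step being a 2.0-fold higher number from compound 1 to compound 4 (0.30 log units; within the scatter). Compound 4 is expected near 70000 nM, within an estimated range of 30000 nM to 150000 nM.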

Compound 4, half-maximal inhibitory concentration: 59000 nM
Compound 4: the middle estimate sits 1.2-fold (0.07 log units) above what was measured, and the stated range covers the measured number.
By their numbers in this assay, from the lowest: compounds 1, 2 and 4 (each within the scatter of the next). At a limit, above all of these: compound 3.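

In this assay, going by these compounds alone, the dec-1-en-1-yl chain with its one double bond keeps compound 4 within the scatter of both shorter saturated chains: a 1.7-fold higher number from compound 1 to compound 4 (0.23 log units; within the scatter), and a 1.2-fold higher number from compound 2 to compound 4 (0.08 log units; within the scatter). Against its decyl counterpart the result is an at least 1.6-fold lower number from compound 3 to compound 4 (0.22 log units; that floor lies within the scatter), so the double bond is not shown to make a real difference. Compound 3 gives only a limit of the assay: the limit of > 100000 nM in this assay, at which 1 of the 4 values shown sits.

From the compounds shown here alone, whether a much shorter chain would lower the number remains open. So does the effect of an amine or a carboxylic acid placed on the chain.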